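Swapping one aryl methyl for fluorine

The compounds below may be only part of what the source reports. "The series", "measured", "known", "first", "only" and "open" are said of these compounds alone.

In a functional assay on KB cells (Homo sapiens) for antiproliferative activity, read by sulforhodamine B assay, with a stated time of 3 days (on this read-out higher numbers stand for an effect only at larger amounts of compound and lower numbers for an effect already at smaller amounts), compound 3 (`CCC1=C(O)c2c(oc(-c3cc(C)cc(C)c3)cc2=O)C(CC)(CC)C1=O`) gives 45.5 uM, the highest number of the three, against compound 1 (`CCC1=C(O)c2c(oc(-c3ccc(OC)cc3C)cc2=O)C(CC)(CC)C1=O`) at 20.9 uM and compound 2 (`CCC1=C(O)c2c(oc(-c3cc(C)c(O)c(C)c3)cc2=O)C(CC)(CC)C1=O`) at 18.3 uM. Compound 4 (`CCC1=C(O)c2c(oc(-c3ccc(F)c(C)c3)cc2=O)C(CC)(CC)C1=O`) is the next case: 4-fluoro-3-methylphenyl in place of 3,5-dimethylphenyl on an aromatic carbon. Three measured steps change the group on this same aromatic carbon. The first two are a 2.2-fold higher number from compound 1 to compound 3 (0.34 log units; beyond the scatter) and a 2.5-fold higher number from compound 2 to compound 3 (0.40 log units; beyond the scatter), both modest, and the third is a 1.1-fold lower number from compound 1 to compound 2 (0.06 log units; within the scatter). Going by the values given here, the closest guide is the second, where hydrogen replaces hydroxy, but no measured compound carries fluorine, so it transfers only loosely. The data therefore support no large move, and at most a partial shift toward the numbers of compound 1 and compound 2. The estimated change is a 1.4-fold lower number from compound 3 to compound 4 (0.15 log units; within the scatter), so no step beyond the scatter is expected, with a slight lean toward a lower number. Compound 4 is estimated at 32 uM, with an expected range of 14 uM to 65 uM.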

Compound 4, concentration for half-maximal effect: 40.5 uM
The estimate for compound 4 lay 1.3-fold (0.10 log units) below the measured number, within the range that was stated.
By their numbers in this assay, from the lowest: compounds 2, 1, 4 and 3 (each within the scatter of the next, the first and the last beyond it).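

In this assay, going by these compounds alone, 4-fluoro-3-methylphenyl in place of 3,5-dimethylphenyl gives no step beyond the scatter (a 1.1-fold lower number from compound 3 to compound 4 (0.05 log units; within the scatter)), so this exchange of an aryl substituent leaves the number where it was, and the first fluorine-bearing aryl group at this aromatic carbon separates from neither neighbour on that side. Compound 4 stays apart from the hydroxy compound (a 2.2-fold higher number from compound 2 to compound 4 (0.35 log units; beyond the scatter)) but, unlike compound 3, does not separate from the methoxy compound (a 1.9-fold higher number from compound 1 to compound 4 (0.29 log units; within the scatter)), so the two groups without hydroxy or methoxy need not sit the same distance from compound 1. Nothing here gives a reason for these numbers.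

From the compounds shown here alone, the names 3,5-dimethylphenyl and 4-fluoro-3-methylphenyl differ in both the group and its ring place, so the effect of fluorine alone stays open. Also open, going by these compounds, is whether an amine, a carboxylic acid or a longer chain such as ethoxy on this aryl ring would move the number beyond the scatter.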